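A few compounds are considered here, and "the series" means these few. Any claim that something is new, unique, unknown or untested is made for them only; others in the source may bear on it.

Measured in a functional assay on BMDM cells (Mus musculus, strain C57BL/6) for inhibition, with a stated time of 2 days; a higher number here means a weaker inhibitor, a lower number a stronger inhibitor:
- compound 1 `CCOC(=O)c1sc(NC(=O)Cn2cc(-c3cccs3)nn2)nc1C` gives 20 nM
- compound 2 `CCOC(=O)c1sc(NC(=O)Cn2cc(-c3ccc(Cl)cc3)nn2)nc1C` gives 180 nM
- compound 3 `CCOC(=O)c1sc(NC(=O)Cn2cc(-c3ccncc3)nn2)nc1C` gives 120 nM

Compound 3 sits with compound 2 at the weak end of the three numbers in this assay: the pair differs by a 1.5-fold lower number from compound 2 to compound 3 (0.18 log units; within the scatter), while the other gap is a 6.0-fold higher number from compound 1 to compound 3 (0.78 log units; beyond the scatter) and is real.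

Compound 4 `CCOC(=O)c1sc(NC(=O)Cn2cc(-c3ccc(C#N)cc3)nn2)nc1C` is the next member. It differs from compound 3 as follows: 4-cyanophenyl in place of pyridin-4-yl on an aromatic carbon

Among the measured compounds shown here, three steps bear on this. The move away from thiophen-2-yl to a six-membered aromatic group cost a 9.0-fold higher number from compound 1 to compound 2 (0.95 log units; beyond the scatter) and a 6.0-fold higher number from compound 1 to compound 3 (0.78 log units; beyond the scatter); the exchange of one six-membered group for another, a 1.5-fold lower number from compound 2 to compound 3 (0.18 log units; within the scatter), stayed inside the scatter. Compound 4 carries a six-membered ring of carbon only with a single substituent, as compound 2 does, so the relevant comparison is between compound 2 and compound 3, which are indistinguishable. No step beyond the scatter is therefore expected in this assay; the estimated step is a 1.3-fold higher number from compound 3 to compound 4 (0.10 log units; within the scatter).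

Compound 4 is estimated at 150 nM, with a range of 60 nM to 400 nM.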

Compound 4, half-maximal inhibitory concentration: 310 nM
Estimate against measurement, compound 4: 2.1-fold (0.32 log units) below; the range from low to high includes it.
By their numbers in this assay, from the lowest: compound 1; then compounds 3, 2 and 4 (each within the scatter of the next, the first and the last beyond it).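

In this assay, the six-membered groups on this aromatic carbon are not fully interchangeable: 4-cyanophenyl separates from pyridin-4-yl (a 2.6-fold higher number from compound 3 to compound 4 (0.41 log units; beyond the scatter)). Yet 4-cyanophenyl cannot be told apart from 4-chlorophenyl (a 1.7-fold higher number from compound 2 to compound 4 (0.24 log units; within the scatter)), so compound 3, compound 2 and compound 4 form a chain in which only the ends are resolved. The gap to thiophen-2-yl is now the widest in the series (a 16-fold higher number from compound 1 to compound 4 (1.19 log units; beyond the scatter)), and compound 1 stands apart from all three six-membered groups. Nothing at hand accounts for these steps.

Open, going by these compounds, is whether the thiophen-2-yl result carries over to furan-2-yl or thiophen-3-yl. Also open, on these data alone, is how an amine on the phenyl ring, as in 4-aminophenyl, or a carboxylic acid in place of the ethyl ester would read here.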